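Working notes: nitro in place of chloro

The source may report more compounds than this note shows. Statements on the series, on what has been measured and on what is new or still open speak of the compounds shown alone.

Measured so far:
compound 1, `Nc1nc(O)c2c(n1)n(C1OC(CO)[C@@H](O)[C@H]1O)c(=O)n2Cc1ccc(Cl)cc1`: 180 uM
compound 2, `C=CCn1c(=S)n([C@@H]2O[C@H](CO)[C@H]3OC(C)(C)O[C@H]32)c2nc(N)nc(O)c21`: 40 uM
compound 3, `C=CCn1c(=S)n(COCCO)c2nc(N)nc(O)c21`: 55 uM

In a functional assay on YAC-1 cells (Mus musculus) for activation (on this read-out lower numbers stand for an effect already at smaller amounts and higher numbers for an effect only at larger amounts of compound), compound 1 gives 180 uM, the highest of the three numbers. Compound 3 lies nearest to it and compound 2 furthest, both at lower numbers and both beyond the scatter. Compound 2 and compound 3 differ from compound 1 in several places at once, so they give no guide to a single change.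

Compound 4, `Nc1nc(O)c2c(n1)n(C1OC(CO)[C@@H](O)[C@H]1O)c(=O)n2Cc1ccc([N+](=O)[O-])cc1`, differs from compound 1 by nitro in place of chloro on an aromatic carbon. Among the measured compounds shown here, no measured pair shows this change, so no step is known for it. In this assay the expected step is a 1.1-fold higher number from compound 1 to compound 4 (0.02 log units; within the scatter), not beyond the scatter and in no clear direction. Compound 4 is estimated at 190 uM, with a range from 60 uM to 600 uM.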

Compound 4, concentration for half-maximal effect: 48 uM
Beside the measured number, compound 4's estimate is 4.0-fold (0.60 log units) above it; the whole stated range lies above it.
By their numbers in this assay, from the lowest: compounds 2, 4 and 3 (each within the scatter of the next); then compound 1.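

In this assay, among the compounds shown here, 4-nitrobenzyl in place of 4-chlorobenzyl gives a 3.8-fold lower number from compound 1 to compound 4 (0.57 log units; beyond the scatter), the first single change that can be read. The number therefore moves with the group on this aromatic carbon, which compounds 2 and 3, differing from compound 1 in several places at once, could not show. Nothing available accounts for the step.

Open, from the compounds shown here alone, is how the number responds to other groups on this carbon, such as an amine, a carboxylic acid or plain hydrogen. Also open, going by these compounds, is whether nitro in place of chloro gives a similar step on another core.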